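Chain amine change on compound 1: dimethylamino to diethylamino

The source may hold more compounds than are shown below. What is called first, only, known or untested is meant among the compounds shown, and "the series" means these compounds.

Going by the values given here, compound 1 `CN(C)CCNc1nc(-c2ccc(NC(=O)Nc3ccccc3Cl)cc2)nc2ccsc12` gives 310 nM in a functional assay on HT-29 cells (Homo sapiens) for cytotoxicity, read by MTT assay, with a stated time of 72 h (a higher number here means a weaker inhibitor, a lower number a stronger inhibitor), the lowest of the two numbers measured so far. Among the compounds with values here, compound 2 `CN(C)CCNc1nc(-c2ccc(NC(=O)Nc3ccc(Cl)cc3Cl)cc2)nc2ccsc12` gives 1320 nM in this assay; the step of a 4.3-fold higher number from compound 1 to compound 2 (0.63 log units; beyond the scatter) is the only measured step and concerns the urea aryl ring, not the amine chain. Compound 3 `CCN(CC)CCNc1nc(-c2ccc(NC(=O)Nc3ccccc3Cl)cc2)nc2ccsc12` differs from compound 1 by diethylamino in place of dimethylamino on a saturated chain carbon, two bonds along the chain from a nitrogen on an aromatic ring. Within the data shown here, no measured step touches this part of the core, so no shift beyond the scatter is expected in this assay. Compound 3 is estimated at 310 nM, range 120 nM to 800 nM, an expected step of no change at the digits printed from compound 1 to compound 3 (within the scatter).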

Compound 3, half-maximal inhibitory concentration: 620 nM
Beside the measured number, compound 3's estimate is 2.0-fold (0.30 log units) below it, and the stated range covers the measured number.
By their numbers in this assay, from the lowest: compounds 1 and 3 (each within the scatter of the next); then compound 2.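

At the chain amine, diethylamino in place of dimethylamino gives a 2.0-fold higher number from compound 1 to compound 3 (0.30 log units; within the scatter) in this assay. This position on the saturated chain therefore accepts the larger dialkylamino group without a shift beyond the scatter, unlike the chloro change on the urea aryl ring. No supporting data on the cause accompany this result.

Open, on these data alone, is whether a cyclic amine such as pyrrolidine or morpholine, a primary amine, or a longer chain carrying the dimethylamino group would stay within the scatter of compound 1. Also open, as far as these compounds go, is whether diethylamino behaves the same way on the compound 2 background.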